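Methoxy in place of trifluoromethyl across two cores

A few compounds are considered here, and "the series" means these few. Any claim that something is new, unique, unknown or untested is made for them only; others in the source may bear on it.

Compound 1 `O=S(=O)(Nc1ccc2oc(-c3ccccc3)nc2c1)c1cccc(C(F)(F)F)c1` opens the set. In an assay on cells for inhibition of HSP60/HSP10 (Homo sapiens), with a stated time of 60 min (a lower number here means a stronger inhibitor, a higher number a weaker inhibitor), compound 1 reaches only the limit of the assay, > 100000 nM. Compound 2 `COc1cccc(S(=O)(=O)Nc2ccc3oc(-c4ccccc4)nc3c2)c1` carries one change relative to compound 1, namely (methoxy in place of trifluoromethyl on an aromatic carbon). In this assay compound 2 likewise sits at the limit of the assay, > 100000 nM. The step that the two limits leave unreadable from compound 1 to compound 2 cannot be sized, since both of its ends rest on (the limit of > 100000 nM in this assay, at which 2 of the 3 values shown sit).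

Compound 3 `O=S(=O)(Nc1ccc(-c2nc3ccccc3o2)cc1)c1ccc(C(F)(F)F)cc1` has the same atoms as compound 1 joined differently; the difference between the two cores is not broken down here. In this assay, among the measured compounds shown here, compound 3 gives 50000 nM, the only number among the three values measured so far.

Compound 4 `COc1ccc(S(=O)(=O)Nc2ccc(-c3nc4ccccc4o3)cc2)cc1` has not yet been measured. It differs from compound 3 by methoxy in place of trifluoromethyl on an aromatic carbon. For the measured compounds named here, this is the same kind of change as the one from compound 1 to compound 2, though the place is not the same: in the measured pair the group stands meta to a large group, in the new pair para to a large group. Going by the values given here, the one measured instance of this change yields no readable size, so the expected step of a 1.2-fold higher number from compound 3 to compound 4 (0.08 log units; within the scatter) is set close to none, wide on either side. Compound 4 is accordingly expected to give 60000 nM in this assay, with a range from 15000 nM to 250000 nM, and a real chance that only a limit is reported.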

Compound 4, half-maximal inhibitory concentration: > 100000 nM
Compound 4: only a limit was reported; the forecaster's own chance of this, stated with the estimate: 40%; middle value at least 1.6-fold (0.22 log units) away from the limit.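

In this assay, methoxy in place of trifluoromethyl on an aromatic carbon, para to a large group, gives an at least 2.0-fold higher number from compound 3 to compound 4 (0.30 log units; that floor lies within the scatter). This step is a floor and not a measured size, since the end at compound 4 is a limit of the assay; the true step may be larger, but the floor alone does not carry the change beyond the scatter. The data show only that the same kind of change leaves both methoxy compounds, compound 2 and compound 4, without a number, and they do not show that the change has the same size in the two cores, since the step in the core of compound 1 cannot be read and the place of the group is not the same in the two pairs, so that the series offers almost nothing to compare: the limit of > 100000 nM in this assay, at which 3 of the 4 values shown sit.

Compound 3 alone holds a number, so how far trifluoromethyl itself contributes to that reading stays unresolved, and a group that would bring the core of compound 3 further into the readable range has yet to appear among the compounds shown. As far as these compounds go, what an amine, a carboxylic acid or a longer chain would give at the same place on the aromatic ring remains open in either core.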